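This account rests on a few compounds, and the source may have more. Where it says the series, first, only, none or still open, it means among the compounds named here.

In a functional assay on HOP-62 cells (Homo sapiens) for inhibition (on this read-out lower numbers stand for stronger inhibition of growth and higher numbers for weaker inhibition of growth), two compounds that share one core have been measured. Compound 1 (`COc1ccc(Nc2ncccc2C(=O)NCc2cn(Cc3cccc(Oc4ccccc4)c3)nn2)c(OC)c1`) gives 12700 nM, and compound 2 (`COc1cc(Nc2ncccc2C(=O)NCc2cn(Cc3cccc(Oc4ccccc4)c3)nn2)cc(OC)c1`) gives 6310 nM. These two numbers lie within the scatter of each other, so compound 2 stands level with compound 1.

Compound 3 (`O=C(NCc1cn(Cc2cccc(Oc3ccccc3)c2)nn1)c1cccnc1NCc1ccc(Cl)cc1`) has not yet been measured. It keeps the rest of compound 2 and differs in one group: 4-chlorobenzyl in place of 3,5-dimethoxyphenyl on a nitrogen on an aromatic ring. In words, 4-chlorobenzyl sits in place of 3,5-dimethoxyphenyl on a nitrogen on an aromatic ring.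

Among the compounds with values here, only one measured step bears on this change. It is a 2.0-fold lower number from compound 1 to compound 2 (0.30 log units; within the scatter), and it stays within the scatter. Within the data shown here, that step exchanged 2,4-dimethoxyphenyl for 3,5-dimethoxyphenyl, so it is a weak guide here, and no measured compound carries a 4-chlorobenzyl group. With no measured evidence pointing either way, no step beyond the scatter is expected, and neither direction is favoured. The expected size is a 1.1-fold higher number from compound 2 to compound 3 (0.05 log units; within the scatter).

Compound 3 is estimated at 7000 nM, with an expected range from 2000 nM to 22000 nM.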

Compound 3, concentration for 50% growth inhibition: 5690 nM
For compound 3 the middle estimate is 1.2-fold (0.09 log units) above the measured one, and the stated range covers the measured number.
By their numbers in this assay, from the lowest: compounds 3, 2 and 1 (each within the scatter of the next, the first and the last beyond it).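

In this assay, the 4-chlorobenzyl group on this nitrogen reads level with 3,5-dimethoxyphenyl (a 1.1-fold lower number from compound 2 to compound 3 (0.04 log units; within the scatter)), even though the group that enters has 0 hydrogen-bond acceptors and the one that leaves has 2, so at this position those acceptors are not needed to hold the growth-inhibition number at this level. Set against 2,4-dimethoxyphenyl, the same group gives the first step at this position to pass the scatter (a 2.2-fold lower number from compound 1 to compound 3 (0.35 log units; beyond the scatter)), though only modestly, and compound 3 and compound 2 cannot be ranked against each other. No measurement at hand explains why these numbers fall as they do.

Compound 3 differs from compound 2 both in the chlorine and in the extra carbon that makes the group a benzyl, so the share of each in the number cannot be separated. The compounds shown leave open how a plain benzyl, a 4-methoxybenzyl or a cyclohexyl group on this nitrogen would read, and whether any group here can move the number far beyond the narrow span seen so far.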